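The compounds below may be only part of what the source reports. "The series", "measured", "known", "first", "only" and "open" are said of these compounds alone.

Three amides that share a nitro- and chloro-bearing benzamide part were tested in an ADME assay on Raji cells (Homo sapiens) for cytotoxicity, with a stated time of 72 h; a higher number here means that more compound is needed for the effect, a lower number that less compound is needed. Compound 1 `O=C(Nc1ccc(-c2nc3ccccc3s2)cc1)c1cc([N+](=O)[O-])ccc1Cl` carries a 1,3-benzothiazol-2-yl group on its aniline ring; in this assay compound 1 gives > 27000 nM, which is a limit of the assay and not a number. Compound 2 `O=C(Nc1ccc(-c2ccccc2)cc1)c1cc([N+](=O)[O-])ccc1Cl` differs from it by phenyl in place of 1,3-benzothiazol-2-yl on an aromatic carbon, and in this assay compound 2 gives > 27000 nM, again a limit. The step recorded is a step that the two limits leave unreadable from compound 1 to compound 2. Compound 3 `O=C(Nc1cccc(-c2nc3ccccc3s2)c1)c1cc([N+](=O)[O-])ccc1Cl` has the same atoms as compound 1 joined differently; the difference between the two cores is not broken down here. In this assay compound 3 gives > 27000 nM, also a limit. Every measured value thus sits at the limit of > 27000 nM in this assay, at which 3 of the 3 values shown sit.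

Compound 4 `O=C(Nc1cccc(-c2ccccc2)c1)c1cc([N+](=O)[O-])ccc1Cl` has not yet been measured. It differs from compound 3 by phenyl in place of 1,3-benzothiazol-2-yl on an aromatic carbon. Among the measured compounds shown here, this is the same kind of change as the one made between compound 1 and compound 2, not the same change, since the surroundings of the place differ: in compound 1 the place is para to a large group, whereas in compound 3 it is meta to a large group. The step expected from compound 3 to compound 4 is a step that the limit leaves unreadable from compound 3 to compound 4, an estimate resting on the unreadable earlier step that the two limits leave unreadable from compound 1 to compound 2 and on (the limit of > 27000 nM in this assay, at which 3 of the 3 values shown sit). Compound 4 is accordingly expected to give 40000 nM in this assay, most likely reported only as a limit, with an estimated range from 20000 nM to 120000 nM.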

Compound 4, half-maximal effective concentration in the Raji assay: > 27000 nM
Compound 4: no number, only a limit (the forecaster's own chance of this, stated with the estimate: 85%); the middle value does not contradict the limit.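

In the Raji assay compound 3 gives > 27000 nM as a limit of the assay and not a number. In the Raji assay compound 4 gives > 27000 nM as a limit of the assay too. No step can be read between the two, and every compound shown sits at that limit: the limit of > 27000 nM in the Raji assay, at which 4 of the 4 values shown sit.

The compounds shown leave open how much of any of them would be needed for the effect, and whether phenyl in place of 1,3-benzothiazol-2-yl shifts that amount at all. In a physicochemical assay for solubility, read by spectrophotometry, in phosphate buffer, measured as kinetic solubility, with a stated time of 18 h, at pH 7.4 (on this read-out lower numbers stand for lower solubility and higher numbers for higher solubility), compound 3 gives 580 nM and compound 4 gives 410 nM with a 1.4-fold lower number from compound 3 to compound 4 (0.15 log units; within the scatter) as the step between them.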